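A few compounds are considered here, and "the series" means these few. Any claim that something is new, unique, unknown or untested is made for them only; others in the source may bear on it.

Compound 3 `Nc1nc(-c2ccco2)nc2sc(-c3ccccc3)nc12` is the starting point for this comparison in a functional assay on CHO cells for antagonist activity at adenosine receptor A2b (Homo sapiens), read by cAMP accumulation, with a stated time of 10 min; on this read-out lower numbers stand for stronger inhibition and higher numbers for weaker inhibition. In this assay compound 3 gives only a limit, > 30000 nM. Compound 1 `Cc1nc(N)c2nc(-c3ccccc3)sc2n1` gives the limit > 30000 nM in this assay. Compound 2 `Nc1nc(-c2ccccc2)nc2sc(-c3ccccc3)nc12` likewise gives the limit > 30000 nM. The steps a step that the two limits leave unreadable from compound 1 to compound 2, a step that the two limits leave unreadable from compound 1 to compound 3 and a step that the two limits leave unreadable from compound 2 to compound 3 cannot be read because every value rests at the limit of > 30000 nM in this assay, at which 3 of the 3 values shown sit. Compound 4 `Nc1nc(-c2ccco2)nc2sc(-c3ccco3)nc12` differs from compound 3 by furan-2-yl in place of phenyl on an aromatic carbon. Among the measured compounds shown here, no measured step bears readably on this change, so nothing beyond the scatter can be expected in either direction. Compound 4 is therefore estimated at 40000 nM, ranging from 10000 nM to 150000 nM, most probably again as a limit. The step that the limit leaves unreadable from compound 3 to compound 4 is thus expected to show no readable change.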

Compound 4, half-maximal inhibitory concentration: > 30000 nM
Compound 4: a limit, no number; the forecaster's own chance of this, stated with the estimate: 85%; the middle value is on the limit's open side.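

Compound 3 and compound 4 both give only a limit in this assay, so no step between them can be read: the limit of > 30000 nM in this assay, at which 4 of the 4 values shown sit.

The compounds shown leave open whether any change on the shared core gives a readable inhibition.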